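A few compounds are considered here, and "the series" means these few. Any claim that something is new, unique, unknown or untested is made for them only; others in the source may bear on it.

Measured in a functional assay on HeLa cells (Homo sapiens) for antiproliferative activity, read by MTT assay, with a stated time of 72 h; on this read-out lower numbers stand for stronger inhibition and higher numbers for weaker inhibition:
- compound 1 `Cc1ccc(N2CCN(C(=S)SCc3ccc4nc(N)nc(N)c4c3)CC2)c(C)c1`: 3190 nM
- compound 2 `Nc1nc(N)c2cc(CSC(=S)N3CCN(c4ccccc4F)CC3)ccc2n1`: 6660 nM
- compound 3 `Nc1nc(N)c2cc(CSC(=S)N3CCN(c4ccc(F)cc4F)CC3)ccc2n1`: 3800 nM

Compound 3, at 3800 nM, lies within the scatter of both other compounds. Compound 4 `Nc1nc(N)c2cc(CSC(=S)N3CCN(c4ccc([N+](=O)[O-])cc4)CC3)ccc2n1` is still unmeasured, and its change from compound 3 is 4-nitrophenyl in place of 2,4-difluorophenyl on an amine nitrogen in a ring. Three measured swaps at this same place bear on it. The largest is modest, a 2.1-fold higher number from compound 1 to compound 2 (0.32 log units; beyond the scatter), and the others stay within the scatter: a 1.2-fold higher number from compound 1 to compound 3 (0.08 log units; within the scatter) and a 1.8-fold lower number from compound 2 to compound 3 (0.24 log units; within the scatter). None of them brings in a nitro group, so the data give no direction. A small change is therefore expected in this assay, with an estimated step of a 1.2-fold higher number from compound 3 to compound 4 (0.07 log units; within the scatter). The estimate for compound 4 is 4500 nM, with an expected range of 1800 nM to 11000 nM.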

Compound 4, half-maximal inhibitory concentration: 1660 nM
Estimate against measurement, compound 4: 2.7-fold (0.43 log units) above; measured number outside the range, below it.
By their numbers in this assay, from the lowest: compounds 4, 1, 3 and 2 (each within the scatter of the next, the first and the last beyond it).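

In this assay this position accepts a nitro group on the phenyl ring with no loss of activity: the change gives a 2.3-fold lower number from compound 3 to compound 4 (0.36 log units; beyond the scatter) and a 4.0-fold lower number from compound 2 to compound 4 (0.60 log units; beyond the scatter) and both steps lie beyond the scatter, while a 1.9-fold lower number from compound 1 to compound 4 (0.28 log units; within the scatter) stays within it. For the compounds shown here, these are the first steps beyond the scatter towards a lower number at this position. Nothing measured here explains them. Still open, from the compounds shown here alone, is whether a phenyl ring bearing an amine or a nitrile in place of the nitro group would give a similar number.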